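Removing One Trifluoromethyl From a Diaryl Urea

This account rests on a few compounds, and the source may have more. Where it says the series, first, only, none or still open, it means among the compounds named here.

Compound 2 `COc1cc(Cl)cc(-c2nn(-c3cccc(NC(=O)Nc4cc(C(F)(F)F)cc(C(F)(F)F)c4)c3)cc2-c2ccncc2)c1` and compound 1 `COc1cc(Cl)cc(-c2nn(-c3cccc(NC(=O)c4ccc(Cl)c(Cl)c4)c3)cc2-c2ccncc2)c1` are built on the same core. In a functional assay on SW-620 cells (Homo sapiens) for inhibition, read by sulforhodamine B assay, with a stated time of 48 h, tested at 10 uM (a lower number here means a stronger effect, a higher number a weaker effect of the compound at the concentration tested), compound 2 gives 7.18%, the lower of the two numbers; compound 1 gives 84.2%, a number far above it, beyond the usual scatter. Compound 3 `COc1cc(Cl)cc(-c2nn(-c3cccc(NC(=O)Nc4cccc(C(F)(F)F)c4)c3)cc2-c2ccncc2)c1` differs from compound 2 in a single place: hydrogen in place of trifluoromethyl on an aromatic carbon. Within the data shown here, no measured pair shows this change, so the step from compound 2 to compound 3 is expected, not known: a modest weakening of a number 22.8 percentage points higher from compound 2 to compound 3 (beyond the scatter) seems likely. Compound 3 is expected to give about 30%, somewhere from 8% to 65%.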

Compound 3, a percentage reported as activity, at one concentration (the size of the read-out at that concentration, not a potency): 11.2%
Compound 3: the middle estimate sits 18.8 percentage points above what was measured; measured number inside the range.
By their numbers in this assay, from the lowest: compounds 2 and 3 (each within the scatter of the next); then compound 1.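

Within this assay hydrogen in place of trifluoromethyl on this aromatic carbon gives a number 4 percentage points higher from compound 2 to compound 3 (within the scatter) and so the second trifluoromethyl is not needed to keep the number low. A far larger change appears with (3-(trifluoromethyl)phenyl)amino in place of 3,4-dichlorophenyl on a carbonyl carbon, which gives a number 73 percentage points lower from compound 1 to compound 3 (beyond the scatter) and so marks that swap as the one that matters here. No measurement shown here gives a reason for either result. Still open, going by these compounds, is what an amine or a carboxylic acid on this same aromatic carbon would do. Also open, on these data alone, is whether the remaining trifluoromethyl can be replaced by hydrogen as well.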